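This account rests on a few compounds, and the source may have more. Where it says the series, first, only, none or still open, it means among the compounds named here.

Three measured compounds:
compound 1 `COc1cc(/C=N/Nc2nc3ccccc3s2)cc(OC)c1O`: 36%
compound 2 `COc1cc(/C=N/N(C)c2nc3ccccc3s2)cc(OC)c1O`: 5%
compound 3 `COc1cc(/C=N/N2C(=O)CSC2=S)cc(OC)c1O`: 59%

In a physicochemical assay on cells (Homo sapiens), with a stated time of 18 h, tested at 1 uM (a lower number here means a stronger effect, a higher number a weaker effect of the compound at the concentration tested), compound 1 gives 36%, the second highest of the three numbers: compound 3 sits higher by a step beyond the scatter, while compound 2 lies far lower, the step of a number 31 percentage points lower from compound 1 to compound 2 (beyond the scatter) coming from a methyl in place of hydrogen on a nitrogen on an aromatic ring. Compound 4 `COc1cc(/C=N/Nc2nc3ccccc3s2)ccc1O` has not yet been measured. It differs from compound 1 in one place: hydrogen in place of methoxy on an aromatic carbon. Within the data shown here, the only measured step concerns a nitrogen, not the carbon-only ring, so no measured step bears on this change. With nothing pointing in either direction, the expected step of a number 4 percentage points higher from compound 1 to compound 4 (within the scatter) is small, within the scatter. Compound 4 is therefore estimated at 40%, between 20% and 65%.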

Compound 4, a percentage reported as activity, at one concentration (the size of the read-out at that concentration, not a potency): 65%
For compound 4 the middle estimate is 25 percentage points below the measured one; low and high end bracket the measured number.
By their numbers in this assay, from the lowest: compound 2; then compound 1; then compounds 3 and 4 (each within the scatter of the next).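

In this assay, hydrogen in place of methoxy, ortho to a hydroxy group, gives a number 29 percentage points higher from compound 1 to compound 4 (beyond the scatter) and so a weaker effect. This shows that the aromatic carbon matters as well as the nitrogen changed in the earlier step, and that the shared core with this methoxy group gives the stronger effect of the pair. Nothing measured here explains the change.

Still open, on these data alone, is whether an ethoxy group, a fluorine atom or an amine at this place would keep the stronger effect. Also open, as far as these compounds go, is whether the remaining methoxy group matters as much.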